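Swapping the sulfonamide cap for an acetamide

This account rests on a few compounds, and the source may have more. Where it says the series, first, only, none or still open, it means among the compounds named here.

The series is followed in an ADME assay on the whole organism (Macaca fascicularis) for metabolic stability, read by LC-MS, using cassette dosing, at a dose of 1 mg/kg by the oral route (a higher number here means that the compound lasts longer, a lower number that the compound disappears faster), where compound 2 `CCCCN(c1nc2c(NS(C)(=O)=O)cccc2o1)[C@H](C)c1ccc(-c2ccccc2-c2nnn[nH]2)cc1` gives 4.7 h. Compound 3 `Cc1ccc(-c2nc(=O)o[nH]2)c(-c2ccc([C@@H](C)N(CC3CC3)c3nc4c(C(=O)O)cccc4o3)cc2)c1` gives 2.8 h in this assay, a number that lies within the scatter of the value of compound 2, so the two cannot be ranked. Compound 1 `C[C@H](c1ccc(-c2cc(Cl)ccc2-c2nc(=O)o[nH]2)cc1)N(CC1CC1)c1nc2c(C(=O)O)cccc2o1` gives 0.8 h, which is lower than compound 2 by an amount beyond the scatter. For the measured compounds named here, the one single-point step among the measured compounds, a 3.5-fold higher number from compound 1 to compound 3 (0.54 log units; beyond the scatter), concerns an exchange on an aromatic carbon far from the nitrogen cap and does not bear on the change considered here.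

Compound 4 `CCCCN(c1nc2c(NC(C)=O)cccc2o1)[C@H](C)c1ccc(-c2ccccc2-c2nnn[nH]2)cc1` differs from compound 2 in one place: acetyl in place of methylsulfonyl on a nitrogen on an aromatic ring. Going by the values given here, no measured pair shows what this exchange does in this assay, so there is nothing on which to build a directional expectation. The account therefore expects compound 4 to stay near compound 2, with a step of a 1.3-fold lower number from compound 2 to compound 4 (0.13 log units; within the scatter) that is estimated to fall within the scatter. For compound 4 the estimated half-life in this assay is 3.5 h, with a range of 1.5 h to 7 h.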

Compound 4, half-life: 2.2 h
Estimate against measurement, compound 4: 1.6-fold (0.20 log units) above; the range from low to high includes it.
By their numbers in this assay, from the lowest: compound 1; then compounds 4, 3 and 2 (each within the scatter of the next, the first and the last beyond it).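

In this assay, for the compounds shown here, the exchange of methanesulfonamido for acetamido gives a 2.1-fold lower number from compound 2 to compound 4 (0.33 log units; beyond the scatter), the first reading of any change at this nitrogen on an aromatic ring. The step is modest, but it shows that the methylsulfonyl and acetyl groups are not interchangeable here, with the higher number belonging to the compound that keeps methylsulfonyl, although this conclusion rests on a single pair. Nothing available here bears on what lies behind this difference.

With only these two caps compared, the compounds shown do not tell whether a free amine, a urea or a longer acyl chain on the same nitrogen would give a higher or a lower number than either group. They also leave open whether this exchange would give a step of similar size and the same direction with a different group on the other nitrogen of the shared core, since a single pair cannot show how far the effect carries beyond compound 2 and compound 4.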